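Triazole nucleoside series: hexyl to 1-hydroxyethyl

This account rests on a few compounds, and the source may have more. Where it says the series, first, only, none or still open, it means among the compounds named here.

Measured so far:
compound 1 `CCCCCCc1cn([C@@H]2O[C@H](CO)[C@@H](O)[C@H]2O)nn1` — > 200000 nM
compound 2 `CCCCCCCCc1cn([C@@H]2O[C@H](CO)[C@@H](O)[C@H]2O)nn1` — 50000 nM
compound 3 `OCc1cn([C@@H]2O[C@H](CO)[C@@H](O)[C@H]2O)nn1` — > 200000 nM

In a functional assay on MOLT-4 cells (Homo sapiens) (on this read-out lower numbers stand for stronger inhibition and higher numbers for weaker inhibition), compound 1 gives only a limit. The same holds for compound 3. Compound 2 alone gives a number, with an at least 4.0-fold lower number from compound 1 to compound 2 (0.60 log units; beyond the scatter) and an at least 4.0-fold higher number from compound 2 to compound 3 (0.60 log units; beyond the scatter); the step that the two limits leave unreadable from compound 1 to compound 3 cannot be read, as the limit of > 200000 nM in this assay, at which 2 of the 3 values shown sit, shows.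

Compound 4 `CC(O)c1cn([C@@H]2O[C@H](CO)[C@@H](O)[C@H]2O)nn1` differs from compound 1 by 1-hydroxyethyl in place of hexyl on an aromatic carbon. The change runs toward compound 3, which carries a hydroxymethyl group at the same place and sits at the limit, so compound 4 is expected to stay at the limit as well, giving a number no higher from compound 1 to compound 4 (the limit leaves the size open). The estimate for compound 4 in this assay is 200000 nM, between 100000 nM and 400000 nM.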

Compound 4, half-maximal inhibitory concentration: > 200000 nM
Compound 4 ended at the assay's limit; the forecaster's own chance of this, stated with the estimate: 85%; the middle value lies on the limit itself.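

Compound 4 gives only a limit, as do compound 1 and compound 3, so no step from either of them to compound 4 can be read: the limit of > 200000 nM in this assay, at which 3 of the 4 values shown sit.

The compounds shown leave open whether compound 1, compound 3 and compound 4 differ at all on this read-out.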